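Aryl Amide Replacing Propyl on an Inactive Scaffold

This account rests on a few compounds, and the source may have more. Where it says the series, first, only, none or still open, it means among the compounds named here.

Compound 1 `C=CC1=C(C(=O)Nc2ccc(OCC)cc2)C(c2ccc(OC)cc2)OC1`: > 100000 nM
Compound 2 `C=CC1=C(C(=O)NCCC)C(c2ccc(OC)cc2)OC1`: > 100000 nM

In a functional assay on SW480 cells (Homo sapiens) for cytotoxicity, read by MTT assay, with a stated time of 24 h (a higher number here means a weaker inhibitor, a lower number a stronger inhibitor), compound 1 gives > 100000 nM, which is a limit of the assay and not a number. In this assay compound 2 gives > 100000 nM, again a limit. Compound 2 therefore stands nowhere definite on the numbers shown: both values are limits, as summed up by the limit of > 100000 nM in this assay, at which 2 of the 2 values shown sit. The step that the two limits leave unreadable from compound 1 to compound 2 cannot be read for size, since both of its ends are limits.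

Compound 3 `C=CC1=C(C(=O)Nc2ccccc2OC)C(c2ccc(OC)cc2)OC1` differs from compound 2 by 2-methoxyphenyl in place of propyl on an amide-type nitrogen. Among the compounds with values here, the only measured step bearing on this change is the unreadable one just named, so it gives neither size nor direction. Compound 1, which carries an aryl group on the same nitrogen, also sits at the limit. Compound 3 is therefore expected to remain at a similar level, an expected step that the limit leaves unreadable from compound 2 to compound 3. The estimate for compound 3 in this assay is 150000 nM, with a range from 50000 nM to 500000 nM.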

Compound 3, half-maximal inhibitory concentration: > 100000 nM
Compound 3: a limit, no number; the forecaster's own chance of this, stated with the estimate: 85%; the middle value does not contradict the limit.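

Compound 3 also sits at a limit of the assay, so no step among compound 1, compound 2 and compound 3 can be read for size or direction: the limit of > 100000 nM in this assay, at which 3 of the 3 values shown sit.

The compounds shown leave open what amide nitrogen substituent, if any, would bring a measurable value in this assay.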